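The source may report more compounds than this note shows. Statements on the series, on what has been measured and on what is new or still open speak of the compounds shown alone.

Of the compounds shown here, two from this study have been measured. Compound 1 `Cn1ncc2c(=O)n(-c3ccccc3)c(SC(C)(C)c3ccccc3)nc21` gives 2200 nM in an assay on isolated protein for inhibition of retinal dehydrogenase 2 (Homo sapiens) (a lower number here means a stronger inhibitor, a higher number a weaker inhibitor), the highest number of the two. Compound 2 `CC(C)C(Sc1nc2c(cnn2C)c(=O)n1-c1ccccc1)c1ccccc1` gives 300 nM in this assay, a lower number than that of compound 1, and the gap between them lies beyond the usual scatter. Among the measured compounds shown here, the two differ in more than one place, so no single step connects them. Compound 3 `CC(Sc1nc2c(cnn2C)c(=O)n1-c1ccccc1)c1cccc(O)c1` has not yet been measured. It differs from compound 1 by a group of 9 heavy atoms (8 carbon, 1 oxygen; one six-membered aromatic ring of carbon only) in place of a group of 9 heavy atoms (9 carbon; one six-membered aromatic ring of carbon only), on a sulfur. Since compound 2 reaches its lower number 300 nM with a different group on that same sulfur, the group on the sulfur does seem to matter, but the data give no direct guide for the change to compound 3. A moderate move toward a lower number is expected, with the step from compound 1 to compound 3 estimated at a 2.8-fold lower number from compound 1 to compound 3 (0.44 log units; beyond the scatter). Compound 3 is expected to give about 800 nM, within a range from 250 nM to 2500 nM.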

Compound 3, half-maximal inhibitory concentration: 100 nM
For compound 3 the middle estimate is 8.0-fold (0.90 log units) above the measured one; the measured number lies below the stated range.
By their numbers in this assay, from the lowest: compound 3; then compound 2; then compound 1.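

Changing only the group on the sulfur gives a 22-fold lower number from compound 1 to compound 3 (1.34 log units; beyond the scatter) in this assay, so a single change at this position can move the number by a large amount. The group that leaves and the group that enters have the same count of heavy atoms and the same kind of aromatic ring, but the entering group has an oxygen in place of a carbon, with 1 hydrogen-bond donor and 1 hydrogen-bond acceptor, and its carbons are arranged differently. No measurement here explains why the number falls.

Whether the oxygen or the different carbon arrangement accounts for the step remains open, and a plain 1-phenylethyl group on the sulfur would help separate the two. How a methoxy group or an amine in place of the oxygen-bearing group would behave is also unknown.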